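The source may report more compounds than this note shows. Statements on the series, on what has been measured and on what is new or still open speak of the compounds shown alone.

Measured so far in a functional assay on cells (T-cell, Mus musculus, strain BALB/c) for inhibition, read by MTT assay, with a stated time of 72 h; on this read-out higher numbers stand for weaker inhibition and lower numbers for stronger inhibition:
compound 1 `COC(=O)c1cc(O)ccc1OC(=O)COc1cc(O)c2c(=O)cc(-c3ccccc3)oc2c1` gives 29500 nM
compound 2 `COC(=O)c1cccc(C)c1OC(=O)COc1cc(O)c2c(=O)cc(-c3ccccc3)oc2c1` gives 39100 nM
compound 3 `COC(=O)c1cc(C)ccc1OC(=O)COc1cc(O)c2c(=O)cc(-c3ccccc3)oc2c1` gives 25700 nM

Compound 3 gives the lowest of the three numbers, yet the steps reaching it do not set it apart: a 1.1-fold lower number from compound 1 to compound 3 (0.06 log units; within the scatter) and a 1.5-fold lower number from compound 2 to compound 3 (0.18 log units; within the scatter), both within the scatter. Likewise a 1.3-fold higher number from compound 1 to compound 2 (0.12 log units; within the scatter) lies within the scatter. None of the changes among compounds 1, 2 and 3 has moved this assay beyond its usual spread.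

Compound 4 `COC(=O)c1ccccc1OC(=O)COc1cc(O)c2c(=O)cc(-c3ccccc3)oc2c1` is the unmeasured member. Relative to compound 3 it differs as follows: hydrogen in place of methyl on an aromatic carbon. Going by the values given here, the steps that bear on this are those in which the same methyl was introduced or relocated, compound 1 to compound 3 and compound 2 to compound 3; each stayed within the scatter. On that basis no step beyond the scatter is expected in this assay from removing the methyl. The expected step is a 1.1-fold higher number from compound 3 to compound 4 (0.04 log units; within the scatter). Compound 4 is therefore estimated at 28000 nM, with a range from 14000 nM to 56000 nM.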

Compound 4, half-maximal inhibitory concentration: 28500 nM
Compound 4: middle estimate off by 1.0-fold (0.01 log units), on the low side; the range from low to high includes it.
By their numbers in this assay, from the lowest: compounds 3, 4, 1 and 2 (each within the scatter of the next).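

Hydrogen now gives a reference point on this aromatic carbon, meta to a methoxycarbonyl group and para to a large group, in this assay: removing the methyl gives one small step (a 1.1-fold higher number from compound 3 to compound 4 (0.04 log units; within the scatter)), and hydrogen in place of hydroxy gives another (a 1.0-fold lower number from compound 1 to compound 4 (0.01 log units; within the scatter)). Hydrogen, methyl and hydroxy on this carbon therefore cannot be told apart on this read-out, whereas the earlier compounds compared only methyl with hydroxy. Removing the methyl of compound 2, placed elsewhere on the ring, also stays within the scatter (a 1.4-fold lower number from compound 2 to compound 4 (0.14 log units; within the scatter)).

Open, as far as these compounds go, is whether a group other than these three on this carbon, such as an amine, a carboxylic acid or a longer chain like butyl, would move the number beyond the scatter. Also open, from the compounds shown here alone, is whether any change on this ring matters more than a change elsewhere in the shared core.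

Nothing available explains why these steps stay so small.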